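The compounds below may be only part of what the source reports. "The series", "measured", "known", "first", "only" and "open" are said of these compounds alone.

The account begins with compound 1 `O=S(=O)(c1ccc(-n2cncn2)cc1)N1CCCc2ccccc21`. In a functional assay on MDA-MB-231 cells (Homo sapiens) for antiproliferative activity, read by fluorescence and SYBR Green assay, with a stated time of 24 h (a lower number here means a stronger inhibitor, a higher number a weaker inhibitor), compound 1 gives > 5000 nM, and that figure is a limit rather than a measured number (the limit of > 5000 nM in this assay, at which 1 of the 3 values shown sits). Two further compounds set the scale of the series. Compound 2 `COc1ccc2c(c1)CCCN2S(=O)(=O)c1ccc(N2CCCC2=O)cc1` gives 20 nM in this assay. Compound 3 `CN1CCN(S(=O)(=O)c2ccc(N3CCC=N3)cc2)c2ccccc21` gives 13 nM in this assay. The compound yet to be measured is compound 4 `O=C1CCCN1c1ccc(S(=O)(=O)N2CCCc3ccccc32)cc1`, which differs from compound 1 in one place (2-oxopyrrolidin-1-yl in place of 1H-1,2,4-triazol-1-yl on an aromatic carbon). Going by the values given here, since compound 1 sits only at a limit, no measured step connects it to compound 4, and the size of the change can only be expected. Compound 4 is expected to be much stronger in this assay than compound 1, by a step well beyond the usual scatter, because compound 2, which carries the same 2-oxopyrrolidin-1-yl group, gives 20 nM. On that basis compound 4 is estimated at 40 nM, within a range of 10 nM to 300 nM. The step this estimate means, an at least 120-fold lower number from compound 1 to compound 4 (2.09 log units; beyond the scatter), is expected to lie far outside the scatter.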

Compound 4, half-maximal inhibitory concentration: 15 nM
Compound 4: the middle estimate sits 2.7-fold (0.43 log units) above what was measured; the measured number falls inside the stated range.
By their numbers in this assay, from the lowest: compounds 3, 4 and 2 (each within the scatter of the next). At a limit, above all of these: compound 1.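

On an aromatic carbon para to a large group, 2-oxopyrrolidin-1-yl in place of 1H-1,2,4-triazol-1-yl gives, in this assay, an at least 330-fold lower number from compound 1 to compound 4 (2.52 log units; beyond the scatter), so this one change on the shared core carries the series from a limit to a measured value. Compound 1 stands at a limit and not at a measured number: the limit of > 5000 nM in this assay, at which 1 of the 4 values shown sits. With 2-oxopyrrolidin-1-yl in place, hydrogen in place of methoxy gives a 1.3-fold lower number from compound 2 to compound 4 (0.12 log units; within the scatter), so the methoxy group leaves no reading beyond the scatter.

As far as these compounds go, it stays open whether the carbonyl of 2-oxopyrrolidin-1-yl matters, and how an open-chain acetamide or a plain pyrrolidine would stand at this place. From the compounds shown here alone, it also stays open how an ethoxy group or a carboxylic acid would stand in place of that methoxy.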